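Swapping Fluoro for Methoxy on the Aryl Ring

The compounds below may be only part of what the source reports. "The series", "measured", "known", "first", "only" and "open" are said of these compounds alone.

Measured in a functional assay on HeLa cells (Homo sapiens) for antiproliferative activity, read by sulforhodamine B assay, with a stated time of 48 h; a lower number here means a stronger inhibitor of growth, a higher number a weaker inhibitor of growth:
compound 1 `COc1ccc(Cn2cc(CNC(=O)c3cn(-c4ccccc4)nc3-c3ccc(F)cc3)nn2)cc1`: 870 nM
compound 2 `COc1ccc(Cn2cc(CNC(=O)c3cn(-c4ccccc4)nc3-c3ccc(F)cc3)nn2)cc1OC`: 200 nM
compound 3 `COc1cc(Cn2cc(CNC(=O)c3cn(-c4ccccc4)nc3-c3ccc(F)cc3)nn2)cc(OC)c1`: 360 nM

Compound 3 holds the second highest number of the three. Its nearest neighbour is compound 2, with a 1.8-fold higher number from compound 2 to compound 3 (0.26 log units; within the scatter); its furthest is compound 1, with a 2.4-fold lower number from compound 1 to compound 3 (0.38 log units; beyond the scatter). Compound 4 `COc1ccc(-c2nn(-c3ccccc3)cc2C(=O)NCc2cn(Cc3cc(OC)cc(OC)c3)nn2)cc1` differs from compound 3 by methoxy in place of fluoro on an aromatic carbon. Among the compounds with values here, none of the measured steps touches this position: the two that lie beyond the scatter, a 4.4-fold lower number from compound 1 to compound 2 (0.64 log units; beyond the scatter) and a 2.4-fold lower number from compound 1 to compound 3 (0.38 log units; beyond the scatter), change only the methoxy pattern on the benzyl group. Within the data shown here, with no step bearing on the change, no move beyond the scatter in this assay is expected, so the step from compound 3 to compound 4 is estimated as a 1.1-fold higher number from compound 3 to compound 4 (0.05 log units; within the scatter). Compound 4 is therefore expected near 400 nM, within 150 nM to 1100 nM.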

Compound 4, concentration for 50% growth inhibition: 12400 nM
Estimate against measurement, compound 4: 31-fold (1.49 log units) below; the measured number lies above the stated range.
By their numbers in this assay, from the lowest: compounds 2 and 3 (each within the scatter of the next); then compound 1; then compound 4.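

Replacing 4-fluorophenyl with 4-methoxyphenyl gives a 34-fold higher number from compound 3 to compound 4 (1.54 log units; beyond the scatter) and so exceeds every step seen among the methoxy patterns on the benzyl group. Within the data shown here, this position, which the earlier compounds left unchanged, therefore responds far more strongly to substitution than those patterns do. Nothing measured here accounts for the size of this loss.

Going by these compounds, whether chloro or hydroxyl at this position would fall nearer compound 3 or compound 4 remains open. Also open, on these data alone, is whether the same change would cost as much alongside the 3,4-dimethoxyphenyl group of compound 2.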